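A ring opened at the amide of compound 4

The source may report more compounds than this note shows. Statements on the series, on what has been measured and on what is new or still open speak of the compounds shown alone.

Compound 1 `CCn1c(C(=O)N[C@@H](CC(=O)OC)C(=O)OC)ccc1C(CC)(CC)c1ccc(OCS(=O)(=O)c2ccccc2)c(C)c1` gives the limit > 50000 nM
Compound 2 `CCn1c(C(=O)N[C@H](C)CO)ccc1C(CC)(CC)c1ccc(OCS(=O)(=O)c2ccccc2)c(C)c1` gives 10000 nM
Compound 3 `CCn1c(C(=O)NC2(CO)CC2)ccc1C(CC)(CC)c1ccc(OCS(=O)(=O)c2ccccc2)c(C)c1` gives 45400 nM

Going by the values given here, in a functional assay on BXPC-3 cells (Homo sapiens) for antiproliferative activity, read by MTT assay, with a stated time of 24 h (a lower number here means a stronger inhibitor, a higher number a weaker inhibitor), compound 3 gives 45400 nM and so holds the higher of the two true numbers, with compound 2 as its only measured neighbour. The value of compound 1 is a limit of the assay and not a number. Compound 4 `CCn1c(C(=O)N[C@H](CO)C(C)C)ccc1C(CC)(CC)c1ccc(OCS(=O)(=O)c2ccccc2)c(C)c1` has not yet been measured. Its difference from compound 3 is 1-(hydroxymethyl)-2-methylpropyl in place of 1-(hydroxymethyl)cyclopropyl on an amide-type nitrogen and in it 1-(hydroxymethyl)-2-methylpropyl stands in place of 1-(hydroxymethyl)cyclopropyl on an amide-type nitrogen. The closest measured step is a 4.5-fold higher number from compound 2 to compound 3 (0.66 log units; beyond the scatter) where the same ring entered in place of 1-(hydroxymethyl)ethyl, which has no ring. The steps of an at least 5.0-fold lower number from compound 1 to compound 2 (0.69 log units; beyond the scatter) and an at least 1.1-fold lower number from compound 1 to compound 3 (0.04 log units; that floor lies within the scatter) start from a limit and give only floors. Leaving the ring may therefore be expected to undo part of the step seen with compound 2. The expected change is a 2.5-fold lower number from compound 3 to compound 4 (0.40 log units; beyond the scatter) and this would be a modest step toward a lower number. In this assay compound 4 is estimated at 18000 nM with an expected range from 6000 nM to 50000 nM around that figure.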

Compound 4, half-maximal inhibitory concentration: 7720 nM
Estimate against measurement, compound 4: 2.3-fold (0.37 log units) above, within the range that was stated.
By their numbers in this assay, from the lowest: compounds 4 and 2 (each within the scatter of the next); then compound 3. At a limit, above all of these: compound 1.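

In this assay, replacing the ring on the amide-type nitrogen with the open 1-(hydroxymethyl)-2-methylpropyl group gave a 5.9-fold lower number from compound 3 to compound 4 (0.77 log units; beyond the scatter), so among the hydroxymethyl-bearing groups it is the 1-(hydroxymethyl)cyclopropyl of compound 3 that stands apart. The two open groups give numbers that cannot be told apart, with a 1.3-fold lower number from compound 2 to compound 4 (0.11 log units; within the scatter), so the added carbon of the open chain shows no readable effect at this position. The step of an at least 6.4-fold lower number from compound 1 to compound 4 (0.81 log units; beyond the scatter) starts from the limit of compound 1 and gives only a floor: the limit of > 50000 nM in this assay, at which 1 of the 4 values shown sits.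

From the compounds shown here alone, compounds 2, 3 and 4 all carry a hydroxymethyl group, so what an amine or a carboxylic acid would give in its place remains open. Going by these compounds, how a longer chain would behave on this nitrogen also remains open.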